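Cyclopropyl to isopropyl on two related cores

The compounds below may be only part of what the source reports. "The series", "measured", "known", "first", "only" and "open" are said of these compounds alone.

Notes on the series. Compound 1 `Cc1nn(C(C)(C)C)c2nc(C3CC3)c(/C=C/[C@@H](O)C[C@@H](O)CC(=O)O)c(-c3ccc(F)cc3)c12` and compound 2 `Cc1nn(C(C)(C)C)c2nc(C(C)C)c(/C=C/[C@@H](O)C[C@@H](O)CC(=O)O)c(-c3ccc(F)cc3)c12` share one core; compound 3 `Cc1cc2nc(C3CC3)c(/C=C/[C@@H](O)C[C@@H](O)CC(=O)O)c(-c3ccc(F)cc3)n2n1` and compound 4 `Cc1cc2nc(C(C)C)c(/C=C/[C@@H](O)C[C@@H](O)CC(=O)O)c(-c3ccc(F)cc3)n2n1` share another. The difference between the two cores is not broken down here. In an in vivo functional assay on the whole organism for inhibition of 3-hydroxy-3-methylglutaryl-coenzyme A reductase (Rattus norvegicus), at a dose of 0.2 mg/kg by the oral route (on this read-out lower numbers stand for a weaker effect and higher numbers for a stronger effect at the one dose given), compound 1 gives 4.5%, compound 2 gives 51.8% and compound 3 gives -27.1%. Compound 3 stands lowest of the three measured numbers, with every gap to the others beyond the scatter.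

The change from compound 1 to compound 2, (isopropyl in place of cyclopropyl on an aromatic carbon), gave the step of a number 47.3 percentage points higher from compound 1 to compound 2 (beyond the scatter). The change from compound 3 to compound 4, (isopropyl in place of cyclopropyl on an aromatic carbon), is the same kind of change, but the place differs: the six-membered aromatic ring holds 2 nitrogen rather than 1, the carbon is ortho to a large group rather than to a 6-carboxy-3,5-dihydroxyhex-1-en-1-yl group, and it lies opposite the ring nitrogen. The change occurs twice among the compounds shown.

Among the measured compounds shown here, because the only earlier step was a number 47.3 percentage points higher from compound 1 to compound 2 (beyond the scatter), a rise is expected from compound 3 to compound 4, estimated at a number 37.1 percentage points higher from compound 3 to compound 4 (beyond the scatter). A single step on another core supports it, so the expected rise is taken smaller than that one. In this assay compound 4 is expected at 10%, within -20% to 40%.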

Compound 4, a percentage reported as inhibition, in the whole organism at one dose (the size of the read-out at that dose, not a potency): -6.1%
Estimate against measurement, compound 4: 16.1 percentage points above, and the stated range covers the measured number.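

In this assay, isopropyl in place of cyclopropyl on the aromatic carbon again raises the read-out on the second core, with a number 21 percentage points higher from compound 3 to compound 4 (beyond the scatter). The direction of the step carries from one core to the other, but its size does not: the same change on two cores in this assay, a number 47.3 percentage points higher (beyond the scatter) from compound 1 to compound 2 and a number 21 percentage points higher (beyond the scatter) from compound 3 to compound 4, 26.3 percentage points apart, beyond the scatter of two such steps

Among the compounds shown here, this shows that on these two cores the sign of the change holds while its size depends on the core, so a step measured on one core does not give the size of the step on the other; with only two pairs at a single dose, it shows neither a general rule for the series, nor a difference in potency, nor what in the cores sets the two steps apart.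

The compounds shown leave open whether the rise belongs to isopropyl in particular or would extend to other groups on that aromatic carbon, such as an ethyl group, a longer chain or an amine. They also leave open whether the step keeps its direction on any third core.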